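Lengthening the Chain Once More in a Chromone Series

The source may hold more compounds than are shown below. What is called first, only, known or untested is meant among the compounds shown, and "the series" means these compounds.

Compound 2 `CN(C)CCCCCCCOc1ccc2oc(-c3ccccc3)cc(=O)c2c1` holds the lowest of the two numbers recorded so far in an assay on isolated protein (Cavia porcellus) with Sigma non-opioid intracellular receptor 1 (Homo sapiens) as the target, read by radioligand binding (a lower number here means a stronger inhibitor, a higher number a weaker inhibitor), where compound 2 gives 165 nM. Within the data shown here, its only measured neighbour is compound 1 `CN(C)CCCCCCOc1ccc2oc(-c3ccccc3)cc(=O)c2c1`, which in this assay gives 432 nM; the step of a 2.6-fold lower number from compound 1 to compound 2 (0.42 log units; beyond the scatter) is the sole comparison of this kind available. Compound 3 `CN(C)CCCCCCCCOc1ccc2oc(-c3ccccc3)cc(=O)c2c1` carries the same change one bond further out: (dimethylamino)methyl in place of dimethylamino on a saturated chain carbon, seven bonds along the chain from an oxygen on an aromatic ring. Because the step of a 2.6-fold lower number from compound 1 to compound 2 (0.42 log units; beyond the scatter) went beyond the scatter toward lower numbers, a further move in the same direction, though perhaps smaller, is expected for compound 3, namely a 1.7-fold lower number from compound 2 to compound 3 (0.22 log units; within the scatter). Whether the gain continues at the same rate cannot be judged from one earlier step alone. For compound 3 the estimate in this assay is 100 nM, with an expected range from 40 nM to 250 nM.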

Compound 3, half-maximal inhibitory concentration: 227 nM
Estimate against measurement, compound 3: 2.3-fold (0.36 log units) below; the measured number falls inside the stated range.
By their numbers in this assay, from the lowest: compounds 2, 3 and 1 (each within the scatter of the next, the first and the last beyond it).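

In this assay, (dimethylamino)methyl in place of dimethylamino, seven bonds along the chain from an oxygen on an aromatic ring, gives a 1.4-fold higher number from compound 2 to compound 3 (0.14 log units; within the scatter) and so does not extend the earlier gain. The earlier change, six bonds along the chain, gave a 2.6-fold lower number from compound 1 to compound 2 (0.42 log units; beyond the scatter) and lay beyond the scatter, so the same change does not have the same size at both places. Read against the shorter end of the series, 2-(dimethylamino)ethyl in place of dimethylamino gives a 1.9-fold lower number from compound 1 to compound 3 (0.28 log units; within the scatter), which leaves compound 3 separated by the scatter from neither compound 1 nor compound 2, and nothing available bears on the reason for this result.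

Going by these compounds, whether a still longer chain, carrying 3-(dimethylamino)propyl or 4-(dimethylamino)butyl at this place, would keep the number in this range remains open. So does the effect of a cyclic amine such as piperidine in place of dimethylamino on any of these chains.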